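The compounds below may be only part of what the source reports. "The series", "measured", "known", "first", "only" and "open" are said of these compounds alone.

Measured compounds in a functional assay on MCF7 cells (Homo sapiens) for antiproliferative activity, read by MTT assay, with a stated time of 72 h; on this read-out lower numbers stand for stronger inhibition and higher numbers for weaker inhibition:
compound 1 `CCNC(=O)c1cc(Oc2ccc(NC(=O)c3nn(-c4ccccc4C)c(=O)cc3C)cc2)ccn1` — 44300 nM
compound 2 `CNC(=O)c1cc(Oc2ccc(NC(=O)c3nn(-c4ccccc4Cl)c(=O)cc3C)cc2F)ccn1` — 136000 nM
compound 3 `CCCNC(=O)c1cc(Oc2ccc(NC(=O)c3nn(-c4ccccc4OC(F)(F)F)c(=O)cc3C)cc2F)ccn1` — 7420 nM

Among these three numbers compound 1 stands second highest. Compound 2 gives 136000 nM, a higher number that lies beyond the scatter, while compound 3 gives 7420 nM, a lower number, also beyond the scatter. No pair of these compounds differs in a single place, so no measured step isolates any one change.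

Compound 4 `CCNC(=O)c1cc(Oc2ccc(NC(=O)c3nn(-c4cccc(C(F)(F)F)c4)c(=O)cc3C)cc2)ccn1` differs from compound 1 in one place: 3-(trifluoromethyl)phenyl in place of 2-methylphenyl on an aromatic nitrogen. Among the measured compounds shown here, with no comparable step on record, the expected step from compound 1 to compound 4 is modest: a 1.5-fold lower number from compound 1 to compound 4 (0.17 log units; within the scatter) is estimated to stay near the scatter, leaning toward a lower number. Compound 4 is therefore expected at 30000 nM, within a range from 8000 nM to 120000 nM.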

Compound 4, half-maximal inhibitory concentration: 40600 nM
For compound 4 the middle estimate is 1.4-fold (0.13 log units) below the measured one, and the stated range covers the measured number.
By their numbers in this assay, from the lowest: compound 3; then compounds 4 and 1 (each within the scatter of the next); then compound 2.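

In this assay, 3-(trifluoromethyl)phenyl in place of 2-methylphenyl on the aromatic nitrogen gives a 1.1-fold lower number from compound 1 to compound 4 (0.04 log units; within the scatter), so at this position the two groups cannot be told apart. The earlier compounds shown here differ in several places at once and could not show this for the group on that nitrogen alone. Nothing available here explains the result.

This step alters both the substituent and where it sits on the phenyl group, and the compounds shown do not separate the two. As far as these compounds go, whether an amine or a carboxylic acid on that phenyl group would also stay within the scatter remains open.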